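The source may hold more compounds than are shown below. What is called first, only, known or untested is meant among the compounds shown, and "the series" means these compounds.

The series shares the core of compound 1 `CCCCCC(C)OC(=O)NC(=O)Nc1c(C(C)C)cccc1C(C)C` and varies only the saturated chain attached through the oxygen next to a carbonyl group. In an assay on microsomes from intestine for inhibition of acyl-CoA:cholesterol acyltransferase (Oryctolagus cuniculus) (on this read-out higher numbers stand for weaker inhibition and lower numbers for stronger inhibition), compound 1 gives 1060 nM. Among the measured compounds shown here, compound 2 `CCCCCCCC(C)OC(=O)NC(=O)Nc1c(C(C)C)cccc1C(C)C` carries a longer chain, and in this assay compound 2 gives 390 nM, the lowest of the two numbers measured so far; its only neighbour is compound 1, whose number is higher. For the measured compounds named here, the step of a 2.7-fold lower number from compound 1 to compound 2 (0.43 log units; beyond the scatter) is the single measured step that bears on the next compound. Compound 3 `CCCCCCCCC(C)OC(=O)NC(=O)Nc1c(C(C)C)cccc1C(C)C` has not been measured in this assay; it differs from compound 2 by methyl in place of hydrogen on a saturated chain carbon, eight bonds along the chain from an oxygen next to a carbonyl group. Going by the values given here, that change extends the same chain again, but by a smaller increment than the one separating compound 1 from compound 2, so a smaller shift in the same direction is expected, since the earlier step of a 2.7-fold lower number from compound 1 to compound 2 (0.43 log units; beyond the scatter) was beyond the scatter yet modest. On that basis the expected change is a 1.5-fold lower number from compound 2 to compound 3 (0.18 log units; within the scatter), which may well fall within the scatter. Compound 3 is estimated at 260 nM, with a range from 120 nM to 550 nM.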

Compound 3, half-maximal inhibitory concentration: 750 nM
Compound 3: the middle estimate sits 2.9-fold (0.46 log units) below what was measured, outside the stated range (above it).
By their numbers in this assay, from the lowest: compounds 2, 3 and 1 (each within the scatter of the next, the first and the last beyond it).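

In this assay, methyl in place of hydrogen on a saturated chain carbon, eight bonds along the chain from an oxygen next to a carbonyl group, gives a 1.9-fold higher number from compound 2 to compound 3 (0.28 log units; within the scatter), so at this position the added carbon produces no shift that can be told from the scatter, whereas the earlier extension did, with a 2.7-fold lower number from compound 1 to compound 2 (0.43 log units; beyond the scatter). Among the compounds shown here, compound 3 also cannot be separated from the shorter compound 1, with a 1.4-fold lower number from compound 1 to compound 3 (0.15 log units; within the scatter), so it lies within the scatter of both neighbours, and the single step beyond the scatter does not grow into a trend with chain length across these compounds. Nothing available explains how the chain acts at this position.

The compounds shown cannot tell whether the response to chain length has levelled off or turned back, and whether a longer chain would separate from compound 2 beyond the scatter remains open. Also open, on these data alone, is what a hydroxyl group or an amine on this chain would do in this assay.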